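Swapping the side group of compound 3

The compounds below may be only part of what the source reports. "The series", "measured", "known", "first", "only" and "open" are said of these compounds alone.

Measured in a functional assay on PC-3 cells (Homo sapiens) for antiproliferative activity, read by MTT assay, with a stated time of 96 h; a lower number here means a stronger inhibitor, a higher number a weaker inhibitor
- Compound 1 `FC(F)(F)Oc1cccc(Nc2nnnc3ccc(N4CCCC4)nc23)c1` gives > 100000 nM (a limit of the assay, not a number)
- Compound 2 `CC(C)N1CCN(c2ccc3nnnc(Nc4cccc(OC(F)(F)F)c4)c3n2)CC1` gives 13800 nM
- Compound 3 `FC(F)(F)Oc1cccc(Nc2nnnc3ccc(N4CCC(N5CCCC5)CC4)nc23)c1` gives 8160 nM

Within the data shown here, compound 3, at 8160 nM, holds one of only two true numbers in this small set. The gap to the other is small (a 1.7-fold lower number from compound 2 to compound 3 (0.23 log units; within the scatter)), so the two cannot be told apart.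

Compound 4 `FC(F)(F)Oc1cccc(Nc2nnnc3ccc(NCC4CCNCC4)nc23)c1` carries ((piperidin-4-yl)methyl)amino in place of the 4-(pyrrolidin-1-yl)piperidin-1-yl of compound 3, on the same aromatic carbon (((piperidin-4-yl)methyl)amino in place of 4-(pyrrolidin-1-yl)piperidin-1-yl on an aromatic carbon).

Among the measured compounds shown here, three measured steps bear on this change. Two start from the pyrrolidin-1-yl of compound 1 and are clear gains (an at least 7.2-fold lower number from compound 1 to compound 2 (0.86 log units; beyond the scatter) and an at least 12-fold lower number from compound 1 to compound 3 (1.08 log units; beyond the scatter)). Compound 4 does not return to that group. The closest guide is the exchange of one larger group for another, which stayed within the scatter (a 1.7-fold lower number from compound 2 to compound 3 (0.23 log units; within the scatter)). None of these steps shows what the hydrogen-bond donors of the new group do, so the uncertainty is wide.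

No step beyond the scatter is therefore expected in this assay. The expected step is small (a 1.2-fold lower number from compound 3 to compound 4 (0.07 log units; within the scatter)). For compound 4 the estimated value is 7000 nM, within an expected range of 1500 nM to 30000 nM.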

Compound 4, half-maximal inhibitory concentration: 8320 nM
For compound 4 the middle estimate is 1.2-fold (0.08 log units) below the measured one; the measured number falls inside the stated range.
By their numbers in this assay, from the lowest: compounds 3, 4 and 2 (each within the scatter of the next). At a limit, above all of these: compound 1.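

In this assay, the entering ((piperidin-4-yl)methyl)amino brings hydrogen-bond donors, which the leaving 4-(pyrrolidin-1-yl)piperidin-1-yl lacks, and has no five-membered non-aromatic ring, yet the two groups cannot be told apart: a 1.0-fold higher number from compound 3 to compound 4 (0.01 log units; within the scatter). The same holds against the 4-isopropylpiperazin-1-yl of compound 2 (a 1.7-fold lower number from compound 2 to compound 4 (0.22 log units; within the scatter)), so on this aromatic carbon three quite different groups now give values within the scatter of one another, and the presence of these donors shows no visible effect in this set. As far as these compounds go, only the pyrrolidin-1-yl of compound 1 stands apart, with an at least 12-fold lower number from compound 1 to compound 4 (1.07 log units; beyond the scatter), and the true size of that step stays unknown, since it rests on a limit of the assay rather than a number: the limit of > 100000 nM in this assay, at which 1 of the 4 values shown sits.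

The compounds shown leave open which feature separates these three groups from pyrrolidin-1-yl, since they differ from it in several ways at once. They also leave open whether a simple amine on a longer chain, a morpholine ring or a carboxylic acid at this position would move the number beyond the scatter in either direction.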